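Fluoro for Methoxy: What to Expect of Compound 4

This account rests on a few compounds, and the source may have more. Where it says the series, first, only, none or still open, it means among the compounds named here.

The measured compounds:
Compound 1 `Cc1[nH]n(-c2ccccn2)c(=O)c1C` — > 10000 nM, a limit of the assay
Compound 2 `COc1ccc(Cc2c(C)[nH]n(-c3nc4ccccc4[nH]3)c2=O)cc1` — 630 nM
Compound 3 `Cc1nn(-c2nc3ccccc3[nH]2)c(O)c1Cc1ccccc1` — 480 nM

In an assay on isolated protein for inhibition of alpha-ketoglutarate-dependent dioxygenase alkB homolog 3 (Homo sapiens), read by polymerase chain reaction, with a stated time of 1 h (a lower number here means a stronger inhibitor, a higher number a weaker inhibitor), compound 2 gives 630 nM. Of the two real numbers in this assay, compound 2 holds the higher one, yet compound 3 at 480 nM sits so close that the two values fall within the usual scatter of each other, so neither can be called the stronger inhibitor. For compound 1 the assay reports no number, only (the limit of > 10000 nM in this assay, at which 1 of the 3 values shown sits).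

Compound 4 `Cc1[nH]n(-c2nc3ccccc3[nH]2)c(=O)c1Cc1ccc(F)cc1` is not yet measured. It differs from compound 2 in one place: fluoro in place of methoxy on an aromatic carbon. Going by the values given here, no pair of measured compounds shows this exchange, so its effect in this assay is unknown from the data. With no evidence that the change matters here, the step from compound 2 to compound 4 is expected to be small, a 1.1-fold higher number from compound 2 to compound 4 (0.05 log units; within the scatter), in no particular direction and not beyond the scatter.

Compound 4 is therefore estimated at 700 nM in this assay, with a likely range from 250 nM to 2000 nM.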

Compound 4, half-maximal inhibitory concentration: 600 nM
Compound 4: the middle estimate sits 1.2-fold (0.07 log units) above what was measured; the measured number falls inside the stated range.
By their numbers in this assay, from the lowest: compounds 3, 4 and 2 (each within the scatter of the next). At a limit, above all of these: compound 1.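

Going from the 4-methoxyphenyl group to the 4-fluorophenyl group gives a 1.1-fold lower number from compound 2 to compound 4 (0.02 log units; within the scatter) in this assay, which is the first exchange at this position that can be read directly, since the earlier compounds offered no pair differing in one place. The group that leaves has two heavy atoms and one hydrogen-bond acceptor, while the group that enters has one heavy atom and no hydrogen-bond acceptor, yet the two compounds cannot be told apart by their numbers, so on this ring, para to a large group, this difference between the two groups does not register in the read-out. Nothing in the data gives a reason for this result.

From the compounds shown here alone, two groups are a narrow sample of one position, so it remains open whether an amine, a carboxylic acid or a longer chain such as butoxy in the same place would also leave the number within the scatter of these two. Going by these compounds, it is equally open whether fluoro in place of methoxy would behave the same way on a different core, because this single pair speaks only for the core it shares.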